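The source may report more compounds than this note shows. Statements on the series, on what has been measured and on what is new or still open speak of the compounds shown alone.

Working notes on the series.

Compound 1 `CN(C(=O)c1ccc(Br)cc1)c1ccc2[nH]c(-c3n[nH]c4ccccc34)cc2n1` carries a 4-bromophenyl on the carbonyl carbon and an unsubstituted core on the other side. In a functional assay on SMMC-7721 cells (Homo sapiens) for antiproliferative activity, read by MTT assay, with a stated time of 72 h (on this read-out higher numbers stand for weaker inhibition and lower numbers for stronger inhibition), compound 1 gives 3460 nM, the lowest of the two numbers reported here. Compound 2 `CN(C(=O)c1ccccc1)c1ccc2[nH]c(-c3n[nH]c4cc(Cl)ccc34)cc2n1` is its counterpart with a chloro on the core and an unsubstituted phenyl on the carbonyl; in this assay compound 2 gives 11300 nM, a higher number than compound 1. Compound 3 `CN(C(=O)c1ccccc1)c1ccc2[nH]c(-c3n[nH]c4cc(C#N)ccc34)cc2n1` reaches only a limit of this assay, > 50000 nM, and no number. Among the measured compounds shown here, the one step that can be sized, an at least 4.4-fold higher number from compound 2 to compound 3 (0.64 log units; beyond the scatter), sits at the limit of > 50000 nM in this assay, at which 1 of the 3 values shown sits, and is therefore only a lower bound on its size.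

Compound 4 `CN(C(=O)Nc1ccccc1)c1ccc2[nH]c(-c3n[nH]c4ccccc34)cc2n1` is compound 1 altered at the carbonyl carbon: anilino in place of 4-bromophenyl on a carbonyl carbon. Neither measured step touches this position, so nothing here sizes the change directly. For the measured compounds named here, with no step to rest on, the expectation for compound 4 is a number close to that of compound 1, with a wide band either way; the expected step is a 1.4-fold higher number from compound 1 to compound 4 (0.16 log units; within the scatter). The estimate for compound 4 in this assay is 5000 nM, between 1500 nM and 20000 nM.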

Compound 4, half-maximal inhibitory concentration: 280 nM
Estimate against measurement, compound 4: 18-fold (1.25 log units) above, outside the stated range (below it).
By their numbers in this assay, from the lowest: compound 4; then compound 1; then compound 2. At a limit, above all of these: compound 3.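

In this assay, among the compounds shown here, a 12-fold lower number from compound 1 to compound 4 (1.09 log units; beyond the scatter) is the first sized change at the carbonyl carbon, and it shows that this position can move the number by a large margin, whereas the earlier sized step lay on the core. The two groups share a six-membered aromatic ring of carbon only, so the change lies in what joins that ring to the carbonyl and in what the ring carries: read one bond further out, (4-bromophenyl)carbonyl gives way to phenylcarbamoyl, the bromine leaves, and the anilino brings a hydrogen-bond donor. No measurement shown here bears on why the number falls, so the step stays an observation with no cause attached.

The compounds shown leave open whether the anilino nitrogen or the loss of the bromine carries the step, a question that an unsubstituted phenyl on the carbonyl of the same core, or a 4-bromoanilino, would address. Also open, from the compounds shown here alone, is how an N-methylanilino or a benzylamino group would read at this carbon, and whether the anilino group keeps its effect with a chloro or a nitrile on the core.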